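Methoxy removal on the pyridine arm: carrying a step across cores

The source may report more compounds than this note shows. Statements on the series, on what has been measured and on what is new or still open speak of the compounds shown alone.

Compound 1 `COc1cnc(C[S+]([O-])c2nc3cc(OC(F)F)ccc3[nH]2)cc1OC` and compound 2 `COc1ccnc(C[S+]([O-])c2nc3cc(OC(F)F)ccc3[nH]2)c1` share one core. In an ADME assay for pharmacokinetics, at pH 7.4 (a higher number here means that the compound lasts longer, a lower number that the compound disappears faster), compound 1 reaches only a limit of the assay, > 200 h, which is the limit of > 200 h in this assay, at which 1 of the 3 values shown sits. In this assay compound 2 gives 51 h. The change between them is hydrogen in place of methoxy on an aromatic carbon, and it brings an at least 3.9-fold lower number from compound 1 to compound 2 (0.59 log units; beyond the scatter).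

Compound 3 `COc1cnc(C[S+]([O-])c2nc3cc(OCC(F)(F)F)ccc3[nH]2)c(C)c1OC` carries a different core; how that core differs from the core of compound 1 is not broken down here. In this assay compound 3 gives 130 h, the highest of the two numbers, with compound 2 the nearest measured value, sitting beyond the scatter below it.

Compound 4 `COc1ccnc(C[S+]([O-])c2nc3cc(OCC(F)(F)F)ccc3[nH]2)c1C` is not yet measured. It differs from compound 3 by hydrogen in place of methoxy on an aromatic carbon. Among the compounds with values here, this is the same kind of change as from compound 1 to compound 2, though the surroundings are not identical: in compound 3 the place is also meta to a methyl group (1 heavy atom), which has no counterpart in compound 1. In this assay the step from compound 3 to compound 4 is expected to be a 4.3-fold lower number from compound 3 to compound 4 (0.64 log units; beyond the scatter), set beside an at least 3.9-fold lower number from compound 1 to compound 2 (0.59 log units; beyond the scatter), and resting on that one earlier instance, whose starting value is a limit and so gives only a floor to the size of the drop. On that basis compound 4 is expected to give about 30 h in this assay, most likely between 12 h and 70 h.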

Compound 4, half-life in the ADME assay: 5 h
The estimate for compound 4 lay 6.0-fold (0.78 log units) above the measured number, and the stated range ends above it.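

In the ADME assay, hydrogen in place of methoxy lowers the number on the second core as well, with a 26-fold lower number from compound 3 to compound 4 (1.41 log units; beyond the scatter), and the direction of the step therefore holds on both cores shown, though this rests on only two pairs. Whether the size of the step carries over cannot be said, because the earlier pair starts from a limit and gives only a floor: the same change on two cores in the ADME assay, an at least 3.9-fold lower number (0.59 log units; beyond the scatter) from compound 1 to compound 2 and a 26-fold lower number (1.41 log units; beyond the scatter) from compound 3 to compound 4; the limit leaves it open whether they differ. In a physicochemical assay for acid dissociation, compound 3 gives 3.72 and compound 4 gives 4.97. The same change thus also gives a higher number here, but a single pair cannot show whether this shift is tied to the drop in half-life: the measured acid dissociation constant of compound 3, 3.72, and of compound 4, 4.97, a number 1.25 log units higher (beyond the scatter).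

From the compounds shown here alone, it remains open how far the size of the drop depends on the core, including the methyl group to which the place is meta in compound 3, and whether the drop would recur on a third core. Also open, going by these compounds, is how a group other than hydrogen or methoxy at this place, such as an ethoxy group, a fluorine atom or an amine, would behave in the ADME assay.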